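Urea series: aryl swap on the tetradecyl chain

A few compounds are considered here, and "the series" means these few. Any claim that something is new, unique, unknown or untested is made for them only; others in the source may bear on it.

Measured compounds:
compound 1 `CCCCCCCC/C=C\CCCCCCCCNC(=O)Nc1c(C)cccc1Cl` gives 180 nM
compound 2 `CCCCCCCCCCCCCCNC(=O)Nc1ccc(F)cc1F` gives 340 nM
compound 3 `CCCCCCCCCCCCCCNC(=O)Nc1c(F)cc(F)cc1F` gives 250 nM

All three were tested in an assay on microsomes from intestinal mucosa for inhibition of acyl-CoA:cholesterol acyltransferase (Oryctolagus cuniculus); a lower number here means a stronger inhibitor, a higher number a weaker inhibitor. Compound 3 stands second highest of the three numbers; its neighbours on either side, compound 2 and compound 1, both lie within the scatter of it, so no order among the three can be read. Within the data shown here, the one step measured so far, fluoro in place of hydrogen on an aromatic carbon, gives a 1.4-fold lower number from compound 2 to compound 3 (0.13 log units; within the scatter) and is itself within the scatter.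

Compound 4 `CCCCCCCCCCCCCCNC(=O)Nc1c(C)cccc1Cl` has not yet been measured. It differs from compound 3 by 2-chloro-6-methylphenyl in place of 2,4,6-trifluorophenyl on an amide-type nitrogen. Among the measured compounds shown here, no measured step bears directly on this aryl exchange. What can be said is that compound 1, which carries the same 2-chloro-6-methylphenyl on a longer unsaturated chain, gives a number within the scatter of compound 3, so the aryl exchange is not expected to move this assay beyond the scatter in either direction. Compound 4 is estimated at 200 nM, with a range of 80 nM to 500 nM, which means an expected step of a 1.3-fold lower number from compound 3 to compound 4 (0.10 log units; within the scatter).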

Compound 4, half-maximal inhibitory concentration: 70 nM
For compound 4 the middle estimate is 2.9-fold (0.46 log units) above the measured one, outside the stated range (below it).
By their numbers in this assay, from the lowest: compound 4; then compounds 1, 3 and 2 (each within the scatter of the next).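

In this assay, among these compounds, the group on the amide-type nitrogen proves able to move the number: with the tetradecyl chain held, 2-chloro-6-methylphenyl in place of 2,4,6-trifluorophenyl gives a 3.6-fold lower number from compound 3 to compound 4 (0.55 log units; beyond the scatter) and in place of 2,4-difluorophenyl gives a 4.9-fold lower number from compound 2 to compound 4 (0.69 log units; beyond the scatter) while the one fluoro step stayed within the scatter. Among the compounds shown here, the chain also counts, as with 2-chloro-6-methylphenyl held, hexyl in place of dec-1-en-1-yl on a saturated chain carbon, eight bonds along the chain from the amide-type nitrogen, gives a 2.6-fold lower number from compound 1 to compound 4 (0.41 log units; beyond the scatter) and no earlier step touched the chain. Nothing available here accounts for either step.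

From the compounds shown here alone, whether the aryl step belongs to the chlorine or to the methyl stays open, and 2,6-dichlorophenyl or 2,6-dimethylphenyl on the tetradecyl chain would separate them. Also open, going by these compounds, is how a saturated hexadecyl or octadecyl chain would compare with tetradecyl under the same aryl group.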